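This account rests on a few compounds, and the source may have more. Where it says the series, first, only, none or still open, it means among the compounds named here.

Measured in a physicochemical assay for solubility, read by HPLC, in phosphate buffer, with a stated time of 4 h, at pH 7.4, tested at 10 mg/mL; a lower number here means a less soluble compound, a higher number a more soluble compound:
- compound 1 `Cc1cc(CCC#N)cc(C)c1Oc1cc(Nc2ccc(C#N)cc2)c(N)cc1C(=O)N(C)C`: 1.08 ug/mL
- compound 2 `Cc1cc(CCC#N)cc(C)c1Oc1cc(Nc2ccc(C#N)cc2)c(N)cc1CN(C)C`: 23.4 ug/mL
- compound 3 `Cc1cc(CCC#N)cc(C)c1Oc1cc(Nc2ccc(C#N)cc2)c(N)cc1COC(=O)C1CC1`: 1.64 ug/mL

Compound 1 stands at the low end of these numbers, level with compound 3 within the scatter and well short of compound 2. Compound 4 `COCc1cc(N)c(Nc2ccc(C#N)cc2)cc1Oc1c(C)cc(CCC#N)cc1C` differs from it thus: methoxymethyl in place of dimethylcarbamoyl on an aromatic carbon. That is, methoxymethyl in place of dimethylcarbamoyl on an aromatic carbon.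

For the measured compounds named here, two measured steps bear on this. The large one, a 22-fold higher number from compound 1 to compound 2 (1.34 log units; beyond the scatter), came with (dimethylamino)methyl. The other, a 1.5-fold higher number from compound 1 to compound 3 (0.18 log units; within the scatter), came with ((cyclopropylcarbonyl)oxy)methyl, which resembles methoxymethyl more closely and so is the better guide. No step beyond the scatter is therefore expected in this assay, with a slight rise at most. The expected step is a 1.7-fold higher number from compound 1 to compound 4 (0.22 log units; within the scatter). Compound 4 is estimated at 1.8 ug/mL, with a range of 0.6 ug/mL to 6 ug/mL.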

Compound 4, solubility: 0.66 ug/mL
Estimate against measurement, compound 4: 2.7-fold (0.44 log units) above, and the stated range covers the measured number.
By their numbers in this assay, from the lowest: compounds 4, 1 and 3 (each within the scatter of the next, the first and the last beyond it); then compound 2.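

In this assay methoxymethyl stands level with dimethylcarbamoyl on this aromatic carbon, with a 1.6-fold lower number from compound 1 to compound 4 (0.21 log units; within the scatter) as the step. Methyl in place of cyclopropylcarbonyl on the oxygen gives a 2.5-fold lower number from compound 3 to compound 4 (0.40 log units; beyond the scatter) as a modest step, so the group on that oxygen can shift the number a little. Methoxy in place of dimethylamino gives a 35-fold lower number from compound 2 to compound 4 (1.55 log units; beyond the scatter) as a large step, and of the four groups shown at this carbon only (dimethylamino)methyl stands apart from the rest.

On these data alone, whether a morpholinomethyl group or a carboxylic acid on this carbon would come up to the level of compound 2 stays open. The data shown offer no explanation for these steps.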